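A few compounds are considered here, and "the series" means these few. Any claim that something is new, unique, unknown or untested is made for them only; others in the source may bear on it.

In an ADME assay on a cell-free system (plasma, Mus musculus, strain CD-1) for protein binding, read by LC-MS, tested at 2 uM (a higher number here means a larger unbound share of the compound, a lower number a smaller unbound share), compound 1 (`Cc1nc(C)c(C(=O)Nc2ccc(F)c(-c3nc4ncc(-c5cccnc5Cl)cn4n3)c2)o1`) gives 0.135 and stands above compound 2 (`O=C(Nc1ccc(F)c(-c2nc3ncc(-c4cccnc4F)cc3[nH]2)c1)N1CCCC1`), which gives 0.0493 with a gap beyond the scatter. Compound 3 (`Cc1nc(C)c(C(=O)Nc2ccc(F)c(-c3nc4ncc(-c5ccccc5Cl)cn4n3)c2)o1`) carries 2-chlorophenyl in place of 2-chloropyridin-3-yl on an aromatic carbon of the core of compound 1 (2-chlorophenyl in place of 2-chloropyridin-3-yl on an aromatic carbon). For the measured compounds named here, no measured pair shows this change, so the expected step (a 1.9-fold lower number from compound 1 to compound 3 (0.29 log units; within the scatter)) rests on the structural change alone: a smaller unbound share, by about the size of the scatter. In this assay compound 3 is estimated at 0.07 (expected range 0.03 to 0.14).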

Compound 3, unbound fraction in the Mus musculus assay: 0.015
For compound 3 the middle estimate is 4.7-fold (0.67 log units) above the measured one; measured number below the stated range.
By their numbers in the Mus musculus assay, from the lowest: compound 3; then compound 2; then compound 1.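

For the compounds shown here, the first measured pair at this position shows that replacing 2-chloropyridin-3-yl with 2-chlorophenyl matters in the Mus musculus assay, giving a 9.0-fold lower number from compound 1 to compound 3 (0.95 log units; beyond the scatter). The two compounds differ only in that one ring atom, so the unbound share is sensitive to this single change. The same change also goes with a lower number in a physicochemical assay for solubility, read by LC-MS, at pH 2, tested at 50 uM (a higher number here means a more soluble compound, a lower number a less soluble compound), where compound 1 gives 4080 nM and compound 3 gives 1800 nM: the measured solubility of compound 1, 4080 nM, and of compound 3, 1800 nM, a 2.3-fold lower number (0.36 log units; beyond the scatter)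

This single pair cannot show whether the step would hold on another core. It also leaves open what a 2-methoxypyridin-3-yl group, or a phenyl ring carrying a carboxylic acid, would give at this position.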